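A few compounds are considered here, and "the series" means these few. Any claim that something is new, unique, unknown or untested is made for them only; others in the source may bear on it.

Measured so far:
- compound 1, `COC(=O)/C=C/c1cccc(N(Cc2ccccc2)C(=O)C2CCCCC2)c1`: > 1000 nM in an assay on isolated protein with Bile acid receptor (Homo sapiens) as the target; on this read-out lower numbers stand for an effect already at smaller amounts and higher numbers for an effect only at larger amounts of compound
- compound 2, `COC(=O)/C=C/c1cccc(N(Cc2ccc(-c3cccc(C(C)=O)c3)cc2)C(=O)C2CCCCC2)c1`: 227 nM in this assay

In this assay compound 1 gives only a limit, > 1000 nM, not a number. Compound 2 therefore stands alone as the only number shown, and the one further value is a limit. Within the data shown here, the single measured step, an at least 4.4-fold lower number from compound 1 to compound 2 (0.64 log units; beyond the scatter), is the whole of the evidence; since it starts from the limit of > 1000 nM in this assay, at which 1 of the 2 values shown sits, its true size is not known beyond being at least modest.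

Compound 3, `COC(=O)/C=C/c1cccc(N(Cc2ccc(-c3ccc(OC(F)(F)F)cc3)cc2)C(=O)C2CCCCC2)c1`, differs from compound 2 in one place: 4-(trifluoromethoxy)phenyl in place of 3-acetylphenyl on an aromatic carbon. Both compound 2 and compound 3 thus carry a second aromatic ring where compound 1 has only hydrogen, and only the group on that ring changes. The measured step bears on this change only indirectly, showing that a ring with a polar group at that place brings a gain; nothing measured tells whether the 4-(trifluoromethoxy)phenyl keeps it. The expectation is therefore a step of about a 1.3-fold higher number from compound 2 to compound 3 (0.12 log units; within the scatter), within the scatter. Compound 3 is estimated at 300 nM in this assay, with a range from 80 nM to 1200 nM.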

Compound 3, half-maximal effective concentration: 264 nM
Beside the measured number, compound 3's estimate is 1.1-fold (0.06 log units) above it, and the stated range covers the measured number.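

Replacing the 3-acetylphenyl with a 4-(trifluoromethoxy)phenyl gives a 1.2-fold higher number from compound 2 to compound 3 (0.07 log units; within the scatter) in this assay, so compound 2 and compound 3 cannot be told apart on this read-out. This position therefore accepts two quite different groups on the added ring with no measurable change, and the gain first seen with compound 2 does not depend on the acetyl group and its carbonyl. Measured against the hydrogen of compound 1, the new ring gives an at least 3.7-fold lower number from compound 1 to compound 3 (0.57 log units; beyond the scatter), a second case of an added substituted ring beating the bare core, though the true size of this step is unknown because it starts from a limit: the limit of > 1000 nM in this assay, at which 1 of the 3 values shown sits.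

The compounds shown leave open how much of the gain comes from the added ring alone, which a plain phenyl with no substituent would help to settle, and whether an amine or a carboxylic acid on that ring would be accepted as well. Compound 2 and compound 3 also differ in both the group and its place on the ring, so a pair such as 3-(trifluoromethoxy)phenyl and 4-(trifluoromethoxy)phenyl would be needed to separate the two.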